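This account rests on a few compounds, and the source may have more. Where it says the series, first, only, none or still open, it means among the compounds named here.

Among the compounds with values here, compound 2, `C[C@]1(COc2ccc(NC(=O)Nc3ccc(Cl)cc3)cc2)Cn2cc([N+](=O)[O-])nc2O1`, is the only member of this small set with a number in a physicochemical assay for solubility, read by HPLC, with a stated time of 4 h, at pH 7 (on this read-out lower numbers stand for lower solubility and higher numbers for higher solubility), where compound 2 gives 6.66 ug/mL. Its partner compound 1, `CC(C)(C)c1ccc(NC(=O)Nc2ccc(OC[C@@]3(C)Cn4cc([N+](=O)[O-])nc4O3)cc2)cc1`, is reported in this assay only as a limit, < 1 ug/mL, the assay floor described as the limit of < 1 ug/mL in this assay, at which 1 of the 2 values shown sits. Within the data shown here, the one measured step, an at least 6.6-fold higher number from compound 1 to compound 2 (0.82 log units; beyond the scatter), therefore has a known lower bound only; its true size may be larger.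

Compound 3, `C[C@]1(COc2ccc(NC(=O)Nc3ccc(C(F)(F)F)cc3)cc2)Cn2cc([N+](=O)[O-])nc2O1`, differs from compound 2 by trifluoromethyl in place of chloro on an aromatic carbon. The measured step from compound 1 to compound 2 exchanged a tert-butyl for a chloro on the same aromatic carbon; the step to compound 3 now replaces that chloro with a trifluoromethyl, a group that enters with four heavy atoms where one leaves, so in the counted atoms it points partway back toward compound 1. On that reading compound 3 is expected to give a somewhat lower number than compound 2, with a 2.2-fold lower number from compound 2 to compound 3 (0.35 log units; beyond the scatter), while staying closer to compound 2 than to the floor reached by compound 1. Compound 3 is thus estimated at 3 ug/mL, within 1 ug/mL to 8 ug/mL.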

Compound 3, solubility: < 1 ug/mL
Compound 3: a limit, no number (the forecaster's own chance of this, stated with the estimate: 20%); middle value at least 3.0-fold (0.47 log units) from the limit.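

In this assay, trifluoromethyl in place of chloro on an aromatic carbon, para to a large group, gives an at least 6.6-fold lower number from compound 2 to compound 3 (0.82 log units; beyond the scatter), and this size is only a lower bound on the true step. Compound 3 is reported only as a limit of the assay, < 1 ug/mL, and not as a number. The earlier pair showed only that tert-butyl and chloro at this position part beyond the scatter; now a second group at the same position also ends at the floor, and compound 2, with chloro, is the only one of the three with a number: the limit of < 1 ug/mL in this assay, at which 2 of the 3 values shown sit.

On these data alone, the two limits leave the step from compound 1 to compound 3 unreadable, so nothing orders tert-butyl and trifluoromethyl at this position, and how far either compound really lies under the floor stays unknown. Also open, as far as these compounds go, is where a methoxy group, an amine or a carboxylic acid on this aromatic carbon would fall in this assay relative to compound 2, and whether any group here would give a higher number than chloro does.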